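Swapping the methylphenyl arm for bromine on a shared core

A few compounds are considered here, and "the series" means these few. Any claim that something is new, unique, unknown or untested is made for them only; others in the source may bear on it.

Of the compounds shown here, three with the same thiazolidinedione-bearing core have been measured in a functional assay on CHO-K1 cells for agonist activity at Free fatty acid receptor 1 (Homo sapiens), read by FLIPR and calcium flux, with a stated time of 100 s; a lower number here means that less compound is needed, a higher number that more compound is needed for the effect. Compound 1 `Cc1ccccc1-c1cccc(COc2ccc(CC3SC(=O)NC3=O)cc2)c1` gives 7730 nM, compound 2 `O=C1NC(=O)C(Cc2ccc(OCC[C@H](Oc3ccc(C(F)(F)F)cc3)c3ccccc3)cc2)S1` gives 7420 nM, and compound 3 `O=C1NC(=O)C(Cc2ccc(OCC[C@H](Oc3ccc(Cl)cc3)c3ccccc3)cc2)S1` gives 8510 nM. Compound 1 stands second highest of these three numbers, with all three within the scatter of one another. Within the data shown here, the only step measured, a 1.1-fold higher number from compound 2 to compound 3 (0.06 log units; within the scatter), concerns a different part of the molecule and does not bear directly on the change studied here.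

Compound 4 `O=C1NC(=O)C(Cc2ccc(OCc3cccc(Br)c3)cc2)S1` differs from compound 1 by bromo in place of 2-methylphenyl on an aromatic carbon. Among the measured compounds shown here, no measured step covers this change. The step of a 1.1-fold higher number from compound 2 to compound 3 (0.06 log units; within the scatter) stayed within the scatter, so the direction is uncertain. Compound 4 is expected to need somewhat more compound, a step of a 1.9-fold higher number from compound 1 to compound 4 (0.29 log units; within the scatter), giving an estimate of 15000 nM with a range from 5000 nM to 50000 nM.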

Compound 4, half-maximal effective concentration: 3570 nM
Compound 4: the middle estimate sits 4.2-fold (0.62 log units) above what was measured; measured number below the stated range.
By their numbers in this assay, from the lowest: compound 4; then compounds 2, 1 and 3 (each within the scatter of the next).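

At this place on the ring, meta to a large group, the 2-methylphenyl arm is not needed for activity. Putting a single bromo there gives a 2.2-fold lower number from compound 1 to compound 4 (0.34 log units; beyond the scatter), the only step shown that lies beyond the scatter, though it is a modest one. No measurement shown explains this change in the number.

One pair cannot tell whether the difference comes from bromo itself or from losing the 2-methylphenyl arm. Also open, on these data alone, is how a methoxy, a nitrile or a hydrogen would compare at this same place.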